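A few compounds are considered here, and "the series" means these few. Any claim that something is new, unique, unknown or untested is made for them only; others in the source may bear on it.

Measured so far: compound 1 `CCCCCCCCCCCCOCC(CN)OCCCCCCCCCCCC` gives 75000 nM in a functional assay on V79 cells (Cricetulus griseus) for cytotoxicity; on this read-out lower numbers stand for stronger inhibition and higher numbers for weaker inhibition; compound 2 `CCCCCCCCCCCCCCCCCCOCC(CN)OCCCCCCCCCCCC` gives 76000 nM in this assay.

On these two numbers compound 2 stands alongside compound 1, the gap being a 1.0-fold higher number from compound 1 to compound 2 (0.01 log units; within the scatter). Compound 3 `CCCCCCCCCCCCCCCCCCOCC(CN)OCCCCCCCCCCCCCCCCCC` carries hexyl in place of hydrogen on a saturated chain carbon, ten or more bonds along the chain from an oxygen on a saturated carbon. Going by the values given here, the only measured step that bears on it is the same change on the other chain, a 1.0-fold higher number from compound 1 to compound 2 (0.01 log units; within the scatter), which lay within the scatter. No step beyond the scatter is therefore expected for compound 3 in this assay. Compound 3 is estimated at 80000 nM, between 40000 nM and 160000 nM. That estimate means an expected step of a 1.1-fold higher number from compound 2 to compound 3 (0.02 log units; within the scatter).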

Compound 3, half-maximal inhibitory concentration: 67000 nM
Estimate against measurement, compound 3: 1.2-fold (0.08 log units) above; low and high end bracket the measured number.
By their numbers in this assay, from the lowest: compounds 3, 1 and 2 (each within the scatter of the next).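

In this assay the hexyl change now reads on both chains of the shared core, and on the second chain it gives a 1.1-fold lower number from compound 2 to compound 3 (0.05 log units; within the scatter), so the extension stays within the scatter there as well. The three compounds therefore cannot be ranked, and lengthening either chain on this core moves the number by no more than the scatter. No supporting data bear on why the read-out stays flat. Still open, going by these compounds, is whether a much shorter chain, or a carboxylic acid in place of the amine, would shift the number beyond the scatter.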